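Amide to urea change carried onto a second core

The source may report more compounds than this note shows. Statements on the series, on what has been measured and on what is new or still open speak of the compounds shown alone.

Measured so far in an assay on NIH3T3 cells for binding affinity to melatonin receptor type 1B (Homo sapiens); a lower number here means a stronger inhibitor, a higher number a weaker inhibitor:
compound 1 `CC(C)C(=O)NCCCc1cccc2oc(CCCCc3ccccc3)cc12`, 83 nM
compound 2 `CCNC(=O)NCCCc1cccc2oc(CCCCc3ccccc3)cc12`, 52 nM
compound 3 `CC(C)C(=O)N[C@H]1CCN(c2cccc3oc(CCCCc4ccccc4)cc23)C1`, 162 nM

Compounds 1 and 2 share one core; compound 3 carries another, and the difference between the two cores is not broken down here. From compound 1 to compound 2 the change is ethylamino in place of isopropyl on a carbonyl carbon, and it gave a 1.6-fold lower number from compound 1 to compound 2 (0.20 log units; within the scatter). Compound 4 `CCNC(=O)N[C@H]1CCN(c2cccc3oc(CCCCc4ccccc4)cc23)C1`, not yet measured, is compound 3 with the same change, (ethylamino in place of isopropyl on a carbonyl carbon), the place being the same in both pairs. With a single prior example, a similarly small step is expected, about a 1.6-fold lower number from compound 3 to compound 4 (0.21 log units; within the scatter), resting on a 1.6-fold lower number from compound 1 to compound 2 (0.20 log units; within the scatter) and on compound 3 at 162 nM. Compound 4 is therefore estimated at 100 nM, expected to fall between 40 nM and 250 nM.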

Compound 4, inhibition constant: 98 nM
For compound 4 the middle estimate is 1.0-fold (0.01 log units) above the measured one, within the range that was stated.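

In this assay, ethylamino in place of isopropyl on a carbonyl carbon gives a 1.7-fold lower number from compound 3 to compound 4 (0.22 log units; within the scatter), and the step reads alike on both cores: the same change on two cores in this assay, a 1.6-fold lower number (0.20 log units; within the scatter) from compound 1 to compound 2 and a 1.7-fold lower number (0.22 log units; within the scatter) from compound 3 to compound 4, 1.0-fold (0.02 log units) apart, within the scatter of two such steps. The size of the step therefore carries over from the core of compound 1 to the core of compound 3 in this one pair of cases. Each step on its own lies within the scatter, which leaves no demonstrated difference between the two groups on either core, and two cores say nothing about a third.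

Open, going by these compounds, is whether a longer chain, such as propylamino, on a carbonyl carbon would give a step beyond the scatter. Also open, on these data alone, is how ethoxy in that place would read on these two cores.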